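This account rests on a few compounds, and the source may have more. Where it says the series, first, only, none or still open, it means among the compounds named here.

Compound 2 `Cc1nc(S(C)(=O)=O)ccc1Oc1ncnc(OC2CCN(C(=O)C(F)(F)F)CC2)c1F` gives 880 nM in a functional assay on isolated protein for inhibition of Glucose-dependent insulinotropic receptor (Rattus norvegicus), read by HTRF and cAMP accumulation (on this read-out lower numbers stand for an effect already at smaller amounts and higher numbers for an effect only at larger amounts of compound), the higher of the two numbers recorded, while compound 1 `Cc1nc(S(C)(=O)=O)ccc1Oc1ncnc(OC2CCN(C(=O)OC3(C(F)(F)F)COC3)CC2)c1F` gives 342 nM. Among the compounds with values here, the one measured step, a 2.6-fold higher number from compound 1 to compound 2 (0.41 log units; beyond the scatter), exchanged a larger carbonyl substituent for trifluoromethyl. Compound 3 `Cc1nc(S(C)(=O)=O)ccc1Oc1ncnc(OC2CCN(C(=O)c3noc(C(C)C)n3)CC2)c1F` moves the other way: 5-isopropyl-1,2,4-oxadiazol-3-yl in place of trifluoromethyl on a carbonyl carbon. Since the larger group on this carbonyl went with the lower number of compound 1 342 nM, a modest decrease is expected, a 2.2-fold lower number from compound 2 to compound 3 (0.34 log units; beyond the scatter). The estimate for compound 3 in this assay is 400 nM, with a range from 150 nM to 1200 nM.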

Compound 3, half-maximal effective concentration: 176 nM
Compound 3: middle estimate off by 2.3-fold (0.36 log units), on the high side; low and high end bracket the measured number.
By their numbers in this assay, from the lowest: compounds 3 and 1 (each within the scatter of the next); then compound 2.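

The exchange of trifluoromethyl for 5-isopropyl-1,2,4-oxadiazol-3-yl on this carbonyl carbon gave a 5.0-fold lower number from compound 2 to compound 3 (0.70 log units; beyond the scatter) in this assay, so a five-membered aromatic ring with 3 hetero atoms is accepted here. Set against (3-(trifluoromethyl)oxetan-3-yl)oxy, the same group gave a 1.9-fold lower number from compound 1 to compound 3 (0.29 log units; within the scatter), so these two groups cannot be told apart on this read-out. Nothing available explains either step. Going by these compounds, whether the ring or its isopropyl carries the change remains open, and so does how a phenyl ring or a tert-butyl group on this carbonyl carbon would read.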